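One Carbon Fewer in the Chain of Compound 4

A few compounds are considered here, and "the series" means these few. Any claim that something is new, unique, unknown or untested is made for them only; others in the source may bear on it.

In a functional assay on A549 cells (Homo sapiens) for antiproliferative activity, read by CCK-8 assay, with a stated time of 72 h (a lower number here means a stronger inhibitor, a higher number a weaker inhibitor), compound 1 (`CCOc1cc(C(C)(C)C)ccc1C1=NC(c2ccc(Cl)cc2)C(c2ccc(Cl)cc2)N1C(=O)NCCCCCCCC(=O)Nc1ccccc1N`) gives 15200 nM and compound 3 (`CCOc1cc(C(C)(C)C)ccc1C1=NC(c2ccc(Cl)cc2)C(c2ccc(Cl)cc2)N1C(=O)NCCCCCCC(=O)Nc1ccccc1N`) gives 16000 nM as its value, two results within the scatter of each other. Compound 2 (`CCOc1cc(C(C)(C)C)ccc1C1=NC(c2ccc(Cl)cc2)C(c2ccc(Cl)cc2)N1C(=O)NCCCCCCCC(=O)NO`), with hydroxy in place of 2-aminophenyl on the amide-type nitrogen, gives 4850 nM instead, so compound 3 sits level with compound 1 at the high, weaker end of this small set.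

Compound 4 (`CCOc1cc(C(C)(C)C)ccc1C1=NC(c2ccc(Cl)cc2)C(c2ccc(Cl)cc2)N1C(=O)NCCCCCC(=O)Nc1ccccc1N`) keeps the shared core and differs from compound 3 only in its chain ((2-aminophenyl)carbamoyl in place of ((2-aminophenyl)carbamoyl)methyl on a saturated chain carbon, five bonds along the chain from an amide-type nitrogen) with (2-aminophenyl)carbamoyl in place of ((2-aminophenyl)carbamoyl)methyl. For the measured compounds named here, the nearest precedent is the same kind of shortening, which gave a 1.1-fold higher number from compound 1 to compound 3 (0.02 log units; within the scatter) and so no real change. The steps of a 3.1-fold lower number from compound 1 to compound 2 (0.50 log units; beyond the scatter) and a 3.3-fold higher number from compound 2 to compound 3 (0.52 log units; beyond the scatter) are larger, but both swap the end group, which compound 4 keeps. One earlier shortening is thin evidence, yet it points to no step beyond the scatter in this assay in either direction. The step expected is no change at the digits printed from compound 3 to compound 4 (within the scatter) by this estimate. Compound 4 is expected at 16000 nM with an estimated range from 8500 nM to 30000 nM in this reading.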

Compound 4, half-maximal inhibitory concentration: 20300 nM
The estimate for compound 4 lay 1.3-fold (0.10 log units) below the measured number, within the range that was stated.
By their numbers in this assay, from the lowest: compound 2; then compounds 1, 3 and 4 (each within the scatter of the next).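

In this assay, for the compounds shown here, removing one more chain carbon again gives no step that stands out from the scatter (a 1.3-fold higher number from compound 3 to compound 4 (0.10 log units; within the scatter)), and the two shortenings taken together stay within it as well (a 1.3-fold higher number from compound 1 to compound 4 (0.13 log units; within the scatter)), so the chain length across compound 1, compound 3 and compound 4 has no measurable effect here. The end group still leaves a gap (a 4.2-fold higher number from compound 2 to compound 4 (0.62 log units; beyond the scatter)), but that step changes the end group and the chain length at once, so it cannot be assigned to either change alone. Nothing shown gives a reason for this flat response to chain length.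

Still open, going by these compounds, is whether a longer chain, or a carboxylic acid as the end group, would move the number beyond the scatter. On these data alone, it is also open whether the hydroxy end group would keep its lower number on the shorter chain of compound 4.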